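Free fraction after swapping an aryl ether group

A few compounds are considered here, and "the series" means these few. Any claim that something is new, unique, unknown or untested is made for them only; others in the source may bear on it.

Measured in an ADME assay on the whole organism (plasma, Rattus norvegicus) for protein binding, using cassette dosing, at a dose of 1 mg/kg; on this read-out higher numbers stand for a larger free fraction and lower numbers for a smaller free fraction:
- compound 1 `C[C@@H](Cn1c(=O)[nH]/c(=N\c2ccc(Oc3nccs3)cc2)n(Cc2ccc(Cl)cc2)c1=O)C(=O)O` gives 0.006
- compound 2 `C[C@@H](Cn1c(=O)[nH]/c(=N\c2ccc(Oc3cccc(F)n3)cc2)n(Cc2ccc(Cl)cc2)c1=O)C(=O)O` gives 0.007
- compound 3 `CC(C)Oc1ccc(/N=c2\[nH]c(=O)n(C[C@H](C)C(=O)O)c(=O)n2Cc2ccc(Cl)cc2)cc1Cl` gives 0.003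

Compound 3, at 0.003, lies within the scatter of compound 1 and beyond the scatter below compound 2. The next compound to be tested is compound 4 `C[C@@H](Cn1c(=O)[nH]/c(=N\c2ccc(OC3CCC3)cc2)n(Cc2ccc(Cl)cc2)c1=O)C(=O)O`, and its difference from compound 3 is this: 4-(cyclobutyloxy)phenyl in place of 3-chloro-4-isopropoxyphenyl on a double-bonded nitrogen. The swap sits on a double-bonded nitrogen.

Within the data shown here, only one measured step offers guidance. In that step, 6-fluoropyridin-2-yl takes the place of 1,3-thiazol-2-yl on an oxygen on an aromatic ring, and the result is a 1.2-fold higher number from compound 1 to compound 2 (0.07 log units; within the scatter). Among the measured compounds shown here, that exchange involves different groups, so it is a loose guide, and no measured step shows the present swap directly. Even so, it suggests that compound 4 may fall close to compound 1 at 0.006. The expected change is small and upward, an estimated 2.0-fold higher number from compound 3 to compound 4 (0.30 log units; within the scatter). For compound 4 the estimated value is 0.006, with an expected range of 0.003 to 0.012.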

Compound 4, unbound fraction: 0.015
Estimate against measurement, compound 4: 2.5-fold (0.40 log units) below; the measured number lies above the stated range.
By their numbers in this assay, from the lowest: compounds 3, 1 and 2 (each within the scatter of the next, the first and the last beyond it); then compound 4.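

In this assay, the group on the double-bonded nitrogen can shift the free fraction beyond the scatter, as 4-(cyclobutyloxy)phenyl in place of 3-chloro-4-isopropoxyphenyl gives a 5.0-fold higher number from compound 3 to compound 4 (0.70 log units; beyond the scatter). Cyclobutyl on the oxygen also separates from the two aromatic groups there, which stayed within the scatter of each other: it gives a 2.1-fold higher number from compound 2 to compound 4 (0.33 log units; beyond the scatter) and a 2.5-fold higher number from compound 1 to compound 4 (0.40 log units; beyond the scatter). A non-aromatic carbon group on that oxygen is not enough by itself, though, as compound 3 carries isopropyl there and does not share the larger free fraction.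

The step to compound 4 removes the chlorine and changes isopropoxy to cyclobutyloxy together, so the two changes cannot be told apart, and nothing shown accounts for the rise. From the compounds shown here alone, it also remains open how an amine or a longer carbon chain on that oxygen would read.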